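Triazole-linked catechol series: methylation of a phenolic hydroxyl

This account rests on a few compounds, and the source may have more. Where it says the series, first, only, none or still open, it means among the compounds named here.

Measured so far:
compound 1 `COc1ccc(-n2cc(-c3cc(O)cc(O)c3)nn2)cc1O` — > 10000 nM
compound 2 `COc1ccc(-c2cn(-c3ccc(OC(F)(F)F)cc3)nn2)cc1O` — > 10000 nM

In a functional assay on MDA-MB-231 cells (Homo sapiens) for cytotoxicity, read by MTT assay (a higher number here means a weaker inhibitor, a lower number a stronger inhibitor), compound 1 gives only a limit, > 10000 nM. Compound 2 likewise gives only a limit, > 10000 nM. Both sit at the limit of > 10000 nM in this assay, at which 2 of the 2 values shown sit, so compound 1 stands at the edge of what this assay can report, with no number to rank.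

Compound 3 `COc1ccc(-n2cc(-c3cc(O)cc(O)c3)nn2)cc1OC` differs from compound 1 by methyl in place of hydrogen on an oxygen on an aromatic ring. For the measured compounds named here, no step between measured compounds is available. In this assay the change is expected to give no step beyond the scatter. For compound 3 the estimate is 20000 nM, range 8000 nM to 60000 nM, meaning an expected step that the limit leaves unreadable from compound 1 to compound 3.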

Compound 3, half-maximal inhibitory concentration: > 10000 nM
Compound 3 was reported as a limit; the forecaster's own chance of this, stated with the estimate: 85%; the middle value does not contradict the limit.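

Compound 3, like compound 1, is reported in this assay only as a limit, so no step between the two can be read: the limit of > 10000 nM in this assay, at which 3 of the 3 values shown sit.

The compounds shown leave open whether hydroxy to methoxy changes cytotoxicity at all, as none of them gives a number to rank.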